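Carbamoyl in Place of Acetoxymethyl: an Expected Cytotoxicity Value

This account rests on a few compounds, and the source may have more. Where it says the series, first, only, none or still open, it means among the compounds named here.

Compound 1 `CC(=O)OC[C@H]1CN(c2ccc(-n3cc(-c4ccccn4)cn3)c(F)c2)C(=O)O1` gives > 400 ug/mL.
Compound 2 `O=C(OC[C@H]1CN(c2ccc(-n3cc(-c4ccccn4)cn3)c(F)c2)C(=O)O1)c1ccccc1` gives > 400 ug/mL.
Compound 3 `COC[C@H]1CN(c2ccc(-n3cc(-c4ccccn4)cn3)c(F)c2)C(=O)O1` gives > 400 ug/mL.

In an ADME assay on HEK293-A cells (Homo sapiens) for cytotoxicity, read by MTT assay, with a stated time of 48 h (a lower number here means a stronger inhibitor, a higher number a weaker inhibitor), compound 1 gives > 400 ug/mL, which is a limit of the assay and not a number. Compound 2 likewise gives > 400 ug/mL, a limit. Compound 3 gives > 400 ug/mL, again a limit. All three sit at the limit of > 400 ug/mL in this assay, at which 3 of the 3 values shown sit, so the steps a step that the two limits leave unreadable from compound 1 to compound 2, a step that the two limits leave unreadable from compound 1 to compound 3 and a step that the two limits leave unreadable from compound 2 to compound 3 have no readable size. Compound 4 `NC(=O)[C@H]1CN(c2ccc(-n3cc(-c4ccccn4)cn3)c(F)c2)C(=O)O1` differs from compound 1 by carbamoyl in place of acetoxymethyl on a saturated ring carbon. The measured steps that touch the same saturated ring carbon bear on this change only loosely, and none of them reads. Compound 4 is therefore expected to remain at the limit, with an estimate of 500 ug/mL (range 300 ug/mL to 2000 ug/mL). The expected step that the limit leaves unreadable from compound 1 to compound 4 is none beyond the scatter.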

Compound 4, half-maximal inhibitory concentration: 152 ug/mL
For compound 4 the middle estimate is 3.3-fold (0.52 log units) above the measured one; measured number below the stated range.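

In this assay, the saturated ring carbon next to the ring oxygen gives its first readable response, with carbamoyl producing an at least 2.6-fold lower number from compound 1 to compound 4 (0.42 log units; beyond the scatter), an at least 2.6-fold lower number from compound 3 to compound 4 (0.42 log units; beyond the scatter) and an at least 2.6-fold lower number from compound 2 to compound 4 (0.42 log units; beyond the scatter). The steps among the three earlier compounds cannot be read, so they could not show that this position affects the value at all. Only compound 4 gives a number, and the other compounds remain at a limit: the limit of > 400 ug/mL in this assay, at which 3 of the 4 values shown sit.

From the compounds shown here alone, the size of each step remains open, since each is only a lower bound. Also open, going by these compounds, is whether a carboxylic acid, an aminomethyl group or a longer chain ending in carbamoyl on this carbon would give a value like that of compound 4.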